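Fluorinated acyl variants on the shared core: estimate for compound 4

The source may report more compounds than this note shows. Statements on the series, on what has been measured and on what is new or still open speak of the compounds shown alone.

Measured compounds:
compound 1 `Cc1nc(S(C)(=O)=O)ccc1Oc1ncnc(OC2CCN(C(=O)OC(C)F)CC2)c1F` — 65.5 nM
compound 2 `Cc1nc(S(C)(=O)=O)ccc1Oc1ncnc(OC2CCN(C(=O)OC3(C(F)(F)F)CCC3)CC2)c1F` — 14.3 nM
compound 3 `Cc1nc(S(C)(=O)=O)ccc1Oc1ncnc(OC2CCN(C(=O)C(C)(F)F)CC2)c1F` — 37 nM

In a functional assay on isolated protein for inhibition of Glucose-dependent insulinotropic receptor (Homo sapiens), read by HTRF and cAMP accumulation (on this read-out lower numbers stand for an effect already at smaller amounts and higher numbers for an effect only at larger amounts of compound), compound 2 stands lowest of the three numbers; its nearest neighbour is compound 3 at a 2.6-fold higher number from compound 2 to compound 3 (0.41 log units; beyond the scatter), and compound 1 is furthest at a 4.6-fold lower number from compound 1 to compound 2 (0.66 log units; beyond the scatter).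

The next compound is compound 4 `Cc1nc(S(C)(=O)=O)ccc1Oc1ncnc(OC2CCN(C(=O)C3(F)CCC3)CC2)c1F`. It differs from compound 2 in one place: a group of 5 heavy atoms (4 carbon, 1 fluorine; one four-membered non-aromatic ring of carbon only) in place of a group of 9 heavy atoms (5 carbon, 1 oxygen, 3 fluorine; one four-membered non-aromatic ring of carbon only), on a carbonyl carbon.

Going by the values given here, two measured steps bear on this. The step of a 2.6-fold higher number from compound 2 to compound 3 (0.41 log units; beyond the scatter) also removes the oxygen on the carbonyl carbon and most of the fluorine, though it gives up the four-membered ring as well. The step of a 1.8-fold lower number from compound 1 to compound 3 (0.25 log units; within the scatter), which likewise exchanges an oxygen for a carbon on the carbonyl carbon, stayed within the scatter. Compound 4 keeps the four-membered non-aromatic ring but loses the oxygen and two of the three fluorines, so a modest rise in this assay is expected, smaller than or similar to the rise seen toward compound 3.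

Compound 4 is therefore expected at 30 nM, with a range of 12 nM to 75 nM, an estimated step of a 2.1-fold higher number from compound 2 to compound 4 (0.32 log units; beyond the scatter).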

Compound 4, half-maximal effective concentration: 24.7 nM
Beside the measured number, compound 4's estimate is 1.2-fold (0.08 log units) above it, within the range that was stated.
By their numbers in this assay, from the lowest: compounds 2, 4, 3 and 1 (each within the scatter of the next, the first and the last beyond it).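

Notes on the group on the carbonyl carbon whose other neighbour is the amide-type nitrogen in a ring, read in this assay: a 1.7-fold higher number from compound 2 to compound 4 (0.24 log units; within the scatter) shows that this position tolerates loss of the oxygen and the trifluoromethyl together when the four-membered ring of carbon only is kept, and the entering group counts no hydrogen-bond acceptor. Compound 3, which has no ring, gave a step from compound 2 that was beyond the scatter, yet a 1.5-fold lower number from compound 3 to compound 4 (0.18 log units; within the scatter) also stays within the scatter, so the oxygen-free groups of compound 3 and compound 4 cannot be told apart here. With a 2.7-fold lower number from compound 1 to compound 4 (0.42 log units; beyond the scatter) beyond the scatter, both ring-bearing groups, in compound 2 and compound 4, now stand clear of compound 1, while compound 3 goes against any simple link to the ring, since it lies neither clear of compound 1 nor clear of compound 4.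

No measurement shown gives a cause for any of these steps. Still open, from the compounds shown here alone, is how the plain cyclobutyl without fluorine, a cyclopentyl, or an amine on this carbonyl carbon would read, and whether the fluorine on the ring of compound 4 matters at all.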